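Trifluoromethyl in Place of Ethyl at an Unresolved Limit

The source may report more compounds than this note shows. Statements on the series, on what has been measured and on what is new or still open speak of the compounds shown alone.

Of the compounds shown here, two have so far been tested in a functional assay on the whole organism (strain Sprague-Dawley) for inhibition, with Rattus norvegicus as the target; on this read-out lower numbers stand for an effect already at smaller amounts and higher numbers for an effect only at larger amounts of compound. Compound 1, `O=C(O)c1cnc2cc(C(F)(F)F)ccc2c1`, gives in this assay only a limit of > 25 mg/kg. Compound 2, `CCc1cccc2c(=O)c(-c3nn[nH]n3)c[nH]c12`, likewise gives in this assay only a limit of > 25 mg/kg. Within the data shown here, both results sit at the limit of > 25 mg/kg in this assay, at which 2 of the 2 values shown sit, so no compound is placed by a resolved number, and compound 2 stands exactly where every value shown stands: at the limit. Among the measured compounds shown here, no step between two measured compounds exists, and compound 1 and compound 2 differ in more than one place, so their two limits show only that neither compound reached the read-out.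

Compound 3, `O=c1c(-c2nn[nH]n2)c[nH]c2c(C(F)(F)F)cccc12`, has not been measured. It differs from compound 2 in one place: trifluoromethyl in place of ethyl on an aromatic carbon. Because compound 2 gives only a limit of > 25 mg/kg, no direction beyond the scatter can be read from the data, and the step from compound 2 to compound 3 is expected to be a number no higher from compound 2 to compound 3 (the limit leaves the size open). Compound 3 is therefore expected to give about 25 mg/kg, within 5 mg/kg to 100 mg/kg, most likely once more as a limit.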

Compound 3, minimum effective dose: > 25 mg/kg
Compound 3: no number, only a limit; the forecaster's own chance of this, stated with the estimate: 70%; the middle value lies on the limit itself.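

In this assay, among these compounds, compound 2 and compound 3 both give only limits, so no step between them can be read, and every result stands at one place: the limit of > 25 mg/kg in this assay, at which 3 of the 3 values shown sit. The compounds shown leave open whether any of them reaches a resolved minimum effective dose, and what trifluoromethyl in place of ethyl does to that dose.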